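Heteroaryl replacement on the shared core: compound 4

The source may hold more compounds than are shown below. What is called first, only, known or untested is meant among the compounds shown, and "the series" means these compounds.

Measured compounds in an assay on CHO-K1 cells for binding affinity to 5-hydroxytryptamine receptor 1B (Homo sapiens); on this read-out higher numbers stand for weaker inhibition and lower numbers for stronger inhibition:
compound 1 `Cc1nc(Cc2ccc3[nH]cc([C@H]4C[C@H](N(C)C)C4)c3c2)n[nH]1` gives 3890 nM
compound 2 `CN(C)[C@H]1C[C@H](c2c[nH]c3ccc(CC(N)=O)cc32)C1` gives 1350 nM
compound 3 `CN(C)[C@H]1C[C@H](c2c[nH]c3ccc(CN4C(=O)NC(C)(C)C4=O)cc32)C1` gives 3800 nM

Compound 1 has the highest of the three numbers in this assay. Compound 3 sits within the scatter of compound 1, so the two values show no separation. Compound 2 is the furthest away: a 2.9-fold lower number from compound 1 to compound 2 (0.46 log units; beyond the scatter), a modest step that follows from carbamoyl in place of 5-methyl-1H-1,2,4-triazol-3-yl on a saturated chain carbon bound to an aromatic carbon.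

Compound 4 `Cc1noc(-c2ccc3[nH]cc([C@H]4C[C@H](N(C)C)C4)c3c2)n1` is not yet measured. It differs from compound 1 as follows: 3-methyl-1,2,4-oxadiazol-5-yl in place of (5-methyl-1H-1,2,4-triazol-3-yl)methyl on an aromatic carbon. In words, 3-methyl-1,2,4-oxadiazol-5-yl in place of (5-methyl-1H-1,2,4-triazol-3-yl)methyl on an aromatic carbon.

Among the measured compounds shown here, no measured step touches this change. For the measured compounds named here, the only step at hand, from compound 1 to compound 2, swaps the heteroaryl ring for carbamoyl while keeping the chain carbon, and it gave a modest shift. Going by the values given here, replacing one five-membered ring with three hetero atoms by another, without the chain carbon, has no precedent among the three compounds. The expected step is therefore small, a 1.6-fold lower number from compound 1 to compound 4 (0.19 log units; within the scatter), at most at the edge of the scatter and with no firm direction. Compound 4 is estimated at 2500 nM, with a range from 700 nM to 9000 nM.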

Compound 4, half-maximal inhibitory concentration: 832 nM
The estimate for compound 4 lay 3.0-fold (0.48 log units) above the measured number; low and high end bracket the measured number.
By their numbers in this assay, from the lowest: compounds 4 and 2 (each within the scatter of the next); then compounds 3 and 1 (each within the scatter of the next).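

In this assay the swap to 3-methyl-1,2,4-oxadiazol-5-yl on the aromatic carbon gives a 4.7-fold lower number from compound 1 to compound 4 (0.67 log units; beyond the scatter) and shows that this place accepts a five-membered aromatic ring held directly on the shared core, with no chain carbon in between. Set against the carbamoylmethyl group of compound 2, the same ring gives a 1.6-fold lower number from compound 2 to compound 4 (0.21 log units; within the scatter) and does not separate from it, so two quite different groups at this place read alike in this assay. The swap from compound 1 changes the ring and removes the chain carbon in one move, so the step cannot be divided between those two changes.

Still open, on these data alone, is how 3-methyl-1,2,4-oxadiazol-5-yl would read on a methylene chain carbon, and how 5-methyl-1H-1,2,4-triazol-3-yl would read directly on the aromatic carbon, as either pair would split the step, and how a nitrile or a primary amine would read at the same place. Nothing at hand bears on why the number moves with this change.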